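A few compounds are considered here, and "the series" means these few. Any claim that something is new, unique, unknown or untested is made for them only; others in the source may bear on it.

Measured so far:
compound 1 `CCCCCCCCCCc1ccc(-c2noc(C3CNC3)n2)cc1`: 65%
compound 2 `CCCCCCCCCCc1ccc(-c2noc([C@@H]3CC[C@H](N)C3)n2)cc1`: 38%
compound 3 `CCCCCCCCCCc1ccc(-c2noc(C(Cl)CCN)n2)cc1`: 5%

In an assay on HeLa cells for inhibition of sphingosine-1-phosphate transporter SPNS2 (Mus musculus), read by LC-MS, tested at 2 uM (on this read-out higher numbers stand for more inhibition at the one concentration tested (going by the name of the read-out) and lower numbers for less inhibition), compound 1 gives 65%, the highest of the three numbers. The nearest number belongs to compound 2, and the furthest to compound 3. Compound 4 `CCCCCCCCCCc1ccc(-c2noc(CC(O)CN)n2)cc1` has not yet been measured. It differs from compound 1 in one place: 3-amino-2-hydroxypropyl in place of azetidin-3-yl on an aromatic carbon. Among the compounds with values here, two measured steps bear on this change. One swaps the four-membered ring for a five-membered ring carrying the amine, and that step is a number 27 percentage points lower from compound 1 to compound 2 (beyond the scatter), a modest change. The other replaces the four-membered ring by an open chain carrying the amine, and that step is a number 60 percentage points lower from compound 1 to compound 3 (beyond the scatter), a large change. The third step, a number 33 percentage points lower from compound 2 to compound 3 (beyond the scatter), also runs from a ring to an open chain and is large as well. The change into compound 4 likewise opens the ring into a chain with the amine, so a large downward step in this assay is expected, though the chain here carries a hydroxyl rather than a chlorine and may not fall quite as far. For compound 4 the estimate is 20%, with a range from 0% to 45%. That amounts to an expected step of a number 45 percentage points lower from compound 1 to compound 4 (beyond the scatter).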

Compound 4, a percentage reported as inhibition, at one concentration (the size of the read-out at that concentration, not a potency): 59%
Estimate against measurement, compound 4: 39 percentage points below, outside the stated range (above it).
By their numbers in this assay, from the lowest: compound 3; then compound 2; then compounds 4 and 1 (each within the scatter of the next).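

In this assay, within the data shown here, the step of a number 6 percentage points lower from compound 1 to compound 4 (within the scatter) shows that this position on the shared core can carry an open chain in place of the azetidin-3-yl ring without a loss that stands out from the scatter, something the earlier compounds gave no sign of. The large fall seen with compound 3 therefore does not hold for open chains in general, as the step of a number 54 percentage points higher from compound 3 to compound 4 (beyond the scatter) separates two chains that both carry the amine, one with a chlorine and the other with a hydroxyl. The step of a number 21 percentage points higher from compound 2 to compound 4 (beyond the scatter) adds that a ring at this position is not needed to reach the higher numbers, since the 3-amino-2-hydroxypropyl chain also sits above the 3-aminocyclopentyl ring.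

Still open, as far as these compounds go, is what the hydroxyl itself contributes, which a plain 3-aminopropyl chain, or a carboxylic acid in place of the amine, would help to test. No measurement at hand explains why these chains differ so much, so the steps stand as observations only.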